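The source may hold more compounds than are shown below. What is called first, only, known or untested is meant among the compounds shown, and "the series" means these compounds.

Measured compounds in an assay on LtK cells with ATP-sensitive inward rectifier potassium channel 11 (Homo sapiens) as the target; on this read-out higher numbers stand for an effect only at larger amounts of compound and lower numbers for an effect already at smaller amounts:
compound 1 `O=C(Nc1c(C(O)(C(F)(F)F)C(F)(F)F)ccc2ccccc12)C1CC1` gives 751 nM
compound 2 `CC(C)OC(=O)Nc1c(C(O)(C(F)(F)F)C(F)(F)F)ccc2ccccc12` gives 1160 nM
compound 3 `O=C(Nc1c(C(O)(C(F)(F)F)C(F)(F)F)ccc2ccccc12)c1cccc(Br)c1` gives 80 nM

Compound 3 gives the lowest of the three numbers: the step of a 9.4-fold lower number from compound 1 to compound 3 (0.97 log units; beyond the scatter) and the step of a 15-fold lower number from compound 2 to compound 3 (1.16 log units; beyond the scatter) both lie beyond the scatter, whereas a 1.5-fold higher number from compound 1 to compound 2 (0.19 log units; within the scatter) stays within it. Compound 4 `N#Cc1cccc(C(=O)Nc2c(C(O)(C(F)(F)F)C(F)(F)F)ccc3ccccc23)c1` is not yet measured. It differs from compound 3 by cyano in place of bromo on an aromatic carbon. For the measured compounds named here, no measured step swaps one substituent on the aryl ring for another; the two steps beyond the scatter each replace the whole group on the carbonyl carbon, so they only establish that the aryl amide sits well below the cyclopropyl and isopropoxy analogues and give no guide to the size or direction of a bromo-to-cyano exchange. The step of a 1.6-fold higher number from compound 3 to compound 4 (0.21 log units; within the scatter) is therefore expected to be small, with a wide range reflecting the absence of a precedent. For compound 4 the estimate in this assay is 130 nM, with a range from 40 nM to 450 nM.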

Compound 4, half-maximal effective concentration: 12 nM
Estimate against measurement, compound 4: 11-fold (1.03 log units) above; measured number outside the range, below it.
By their numbers in this assay, from the lowest: compound 4; then compound 3; then compounds 1 and 2 (each within the scatter of the next).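

In this assay the substituent on the aryl ring carries weight of its own: cyano in place of bromo gives (a 6.7-fold lower number from compound 3 to compound 4 (0.82 log units; beyond the scatter)), so the read-out depends on what sits on that ring and not only on an aryl group replacing cyclopropyl or isopropoxy on the carbonyl carbon. With 3-cyanophenyl the distance to the two non-aryl analogues grows well past that seen with 3-bromophenyl, at (a 63-fold lower number from compound 1 to compound 4 (1.80 log units; beyond the scatter)) and (a 97-fold lower number from compound 2 to compound 4 (1.99 log units; beyond the scatter)), which leaves compound 4 lowest of the series. Nothing among the data shown bears on the reason for the bromo-to-cyano effect.

Open, as far as these compounds go, is whether the nitrile would hold this effect on another carbon of the ring. Also open, from the compounds shown here alone, is where a methoxy group, an amine or a carboxylic acid at this position would fall relative to compound 4, so no trend across substituents can yet be drawn.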